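The source may hold more compounds than are shown below. What is called first, only, known or untested is meant among the compounds shown, and "the series" means these compounds.

The three measured compounds and their numbers in a functional assay on C8166 cells (Homo sapiens) for cytotoxicity, read by MTT assay (on this read-out lower numbers stand for higher toxicity in this test and higher numbers for lower toxicity in this test), are:

compound 1 `Cc1cc(S(N)(=O)=O)ccc1NC(=O)COc1ccc(Cl)cc1NC(=O)c1ccccc1C`, 67300 nM;
compound 2 `Cc1cc(S(N)(=O)=O)ccc1NC(=O)COc1ccc(Cl)cc1NC(=O)c1cccc([N+](=O)[O-])c1`, 58800 nM;
compound 3 `Cc1cc(S(N)(=O)=O)ccc1NC(=O)COc1ccc(Cl)cc1NC(=O)c1ccc(Cl)c(Cl)c1`, 158000 nM.

Compound 1 stands second highest of the three, close to compound 2 and clearly apart from compound 3. Compound 4 `Cc1cc(S(N)(=O)=O)ccc1NC(=O)COc1ccc(Cl)cc1NC(=O)c1cc(Cl)cc(Br)c1` differs from compound 1 in a single place: 3-bromo-5-chlorophenyl in place of 2-methylphenyl on a carbonyl carbon. Two measured steps start from compound 1 and bear on this: a 1.1-fold lower number from compound 1 to compound 2 (0.06 log units; within the scatter) and a 2.3-fold higher number from compound 1 to compound 3 (0.37 log units; beyond the scatter). The step to compound 3, where a phenyl carrying chlorine replaced the same 2-methylphenyl, is the nearer parallel, so a modest rise is expected in this assay. The expected step is a 2.1-fold higher number from compound 1 to compound 4 (0.32 log units; beyond the scatter). Compound 4 is therefore estimated at 140000 nM, within a range from 70000 nM to 280000 nM.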

Compound 4, half-maximal cytotoxic concentration: 114000 nM
For compound 4 the middle estimate is 1.2-fold (0.09 log units) above the measured one; measured number inside the range.
By their numbers in this assay, from the lowest: compounds 2, 1, 4 and 3 (each within the scatter of the next, the first and the last beyond it).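

In this assay, 3-bromo-5-chlorophenyl on this carbonyl carbon cannot be told apart from any of the three earlier groups: compound 4 lies within the scatter of compound 1 (a 1.7-fold higher number from compound 1 to compound 4 (0.23 log units; within the scatter)), compound 3 (a 1.4-fold lower number from compound 3 to compound 4 (0.14 log units; within the scatter)) and compound 2 (a 1.9-fold higher number from compound 2 to compound 4 (0.29 log units; within the scatter)). It therefore sits in the gap between compound 3 and the pair of compound 1 and compound 2, which remain beyond the scatter of each other. No measurement here offers an explanation for these numbers.

From the compounds shown here alone, how a phenyl carrying an amine or a carboxylic acid, or a longer chain in its place, would behave at this position remains open.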